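This account rests on a few compounds, and the source may have more. Where it says the series, first, only, none or still open, it means among the compounds named here.

Compound 1 `O=C(N/N=C/c1ccc(F)cc1)Nc1cc2c(Nc3ccc(F)c(Cl)c3)ncnc2cc1O[C@H]1CCOC1` gives "not active" (no number reported) in a functional assay on HepG2 cells (Homo sapiens) for cytotoxicity, read by MTT assay, with a stated time of 72 h (on this read-out higher numbers stand for weaker inhibition and lower numbers for stronger inhibition), so no single number places it within the series. Among the measured compounds shown here, compound 2 `COc1ccc(/C=N/NC(=O)Nc2cc3c(Nc4ccc(F)c(Cl)c4)ncnc3cc2O[C@H]2CCOC2)c(OC)c1OC` gives 29300 nM and compound 3 `O=C(N/N=C/c1cc(Br)c(O)c(Br)c1)Nc1cc2c(Nc3ccc(F)c(Cl)c3)ncnc2cc1O[C@H]1CCOC1` gives 2740 nM; the one step that joins measured compounds, an 11-fold lower number from compound 2 to compound 3 (1.03 log units; beyond the scatter), shows that the aryl on the carbon with a double bond to nitrogen moves the read-out strongly. Compound 4 `CCN(CC)c1ccc(/C=N/NC(=O)Nc2cc3c(Nc4ccc(F)c(Cl)c4)ncnc3cc2O[C@H]2CCOC2)c(O)c1` differs from compound 1 by 4-(diethylamino)-2-hydroxyphenyl in place of 4-fluorophenyl on a carbon with a double bond to nitrogen. For the measured compounds named here, no measured step covers this exact exchange; the step from compound 2 to compound 3 bears on it only in showing that a hydroxy-bearing aryl at this position can give a number where others give weak or no inhibition. Compound 4 is therefore expected to give a measurable value, estimated at 8000 nM, within 2000 nM to 40000 nM.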

Compound 4, half-maximal inhibitory concentration: 15700 nM
The estimate for compound 4 lay 2.0-fold (0.29 log units) below the measured number, within the range that was stated.
By their numbers in this assay, from the lowest: compound 3; then compounds 4 and 2 (each within the scatter of the next).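

In this assay compound 1 gives "not active" (no number reported) while compound 4 gives 15700 nM, so 4-(diethylamino)-2-hydroxyphenyl in place of 4-fluorophenyl yields a measurable number at this position. Exchange of 2,3,4-trimethoxyphenyl for that group does not separate the two compounds (a 1.9-fold lower number from compound 2 to compound 4 (0.27 log units; within the scatter)). A hydroxy-bearing aryl does not by itself fix the number, as compound 3 and compound 4 show (a 5.7-fold higher number from compound 3 to compound 4 (0.76 log units; beyond the scatter)).

Going by these compounds, whether a plain 4-hydroxyphenyl, a single bromo or a dimethylamino group would hold the lower number remains open. No available data give a cause for these differences.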